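This account rests on a few compounds, and the source may have more. Where it says the series, first, only, none or still open, it means among the compounds named here.

Measured compounds in a functional assay for inhibition, with Rattus norvegicus as the target; on this read-out lower numbers stand for stronger inhibition and higher numbers for weaker inhibition:
- compound 1, `CCc1cc(Br)ccc1C/N=c1\c(O)c(O)\c1=N/C(C)(C)C`, gives 270 nM
- compound 2, `COc1ccc(C/N=c2\c(O)c(O)\c2=N/C(C)(C)C)cc1`, gives 4800 nM
- compound 3, `N#Cc1ccc(CNc2c(NC3CCCC3)c(=O)c2=O)cc1`, gives 9400 nM

Among these three numbers compound 2 stands second highest. Its nearest neighbour is compound 3, whose number lies within the scatter of repeated measurement, so the two cannot be told apart; compound 1 lies far lower, beyond the scatter. Compound 4, `CC(C)(C)/N=c1\c(O)c(O)\c1=N/Cc1ccc(C#N)cc1`, is not yet measured and differs from compound 2 by cyano in place of methoxy on an aromatic carbon. Within the data shown here, no measured pair shows this change alone, and compound 3, which also carries a cyano, differs from compound 2 elsewhere as well, so its value is only a rough hint. The expected step of a 1.1-fold higher number from compound 2 to compound 4 (0.06 log units; within the scatter) is none beyond the scatter. Compound 4 is estimated at 5500 nM, within 1500 nM to 18000 nM.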

Compound 4, half-maximal inhibitory concentration: 270 nM
The estimate for compound 4 lay 20-fold (1.31 log units) above the measured number, outside the stated range (below it).
By their numbers in this assay, from the lowest: compounds 1 and 4 (each within the scatter of the next); then compounds 2 and 3 (each within the scatter of the next).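

At the aromatic carbon para to a large group, the choice of substituent clearly matters in this assay: cyano in place of methoxy gives an 18-fold lower number from compound 2 to compound 4 (1.25 log units; beyond the scatter). Both groups have the same count of heavy atoms and hydrogen-bond acceptors, and neither adds a ring or a net charge, so these counts do not separate them. No measurement shown here explains the step.

As far as these compounds go, whether an amine, a carboxylic acid or a longer chain at this carbon would keep the stronger inhibition remains open. So does whether the same swap would give a similar step on a different core.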